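The source may hold more compounds than are shown below. What is called first, only, known or untested is meant among the compounds shown, and "the series" means these compounds.

Compound 1 `CNC(=O)N1CCCc2ccc(NC(=O)c3cccc(-c4ccn(C)n4)c3)cc21` was examined in a functional assay on MV4-11 cells (Homo sapiens) for antiproliferative activity, with a stated time of 6 days, tested at 6.25 uM (on this read-out lower numbers stand for a weaker effect and higher numbers for a stronger effect at the one concentration tested), where compound 1 gives 99.5%. Its companion compound 2 `CNC(=O)N1CCCc2ccc(NC(=O)c3ccc(-c4ccn(C)n4)cc3)cc21`, which carries the same groups arranged differently on the shared core, gives 97% in this assay. The two numbers lie within the usual scatter of each other, so compound 1 stands alongside compound 2 rather than apart from it, and both sit near the top of what this read-out can report at the single concentration tested.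

Compound 3 `CNC(=O)N1CCCc2ccc(NC(=O)c3cccc(-c4ccn(S(C)(=O)=O)n4)c3)cc21` has not yet been measured. It differs from compound 1 in one place: methylsulfonyl in place of methyl on an aromatic nitrogen. For the measured compounds named here, no measured pair in the set shows what this change does, so any expectation rests on the high numbers of compound 1 and compound 2 alone. On that basis, the step from compound 1 to compound 3 in this assay is expected to be a number 7.5 percentage points lower from compound 1 to compound 3 (within the scatter), at most a small downward shift. Compound 3 is estimated to give 92% in this assay, within a range from 65% to 100%.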

Compound 3, a percentage reported as inhibition, at one concentration (the size of the read-out at that concentration, not a potency): 37%
The estimate for compound 3 lay 55 percentage points above the measured number; the measured number lies below the stated range.
By their numbers in this assay, from the lowest: compound 3; then compounds 2 and 1 (each within the scatter of the next).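

In this assay the aromatic nitrogen of the five-membered ring proves sensitive to what it carries: methylsulfonyl in place of methyl gives a number 62.5 percentage points lower from compound 1 to compound 3 (beyond the scatter) and takes the series out of the high range where compound 1 and compound 2 both stand. For the compounds shown here, the earlier pair showed only that the core tolerates two arrangements of the same groups, whereas this step shows that a change at this one position can by itself remove much of the effect at the single concentration tested. The change swaps 1 heavy atom for 4 and adds 2 hydrogen-bond acceptors, but no measurement here tells which of these differences matters or explains the drop.

The compounds shown leave open how an ethyl group or an acetyl group on this nitrogen would compare with methyl and methylsulfonyl. They also leave open whether a hydrogen alone at this position would keep the high numbers of compound 1.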